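The compounds below may be only part of what the source reports. "The series", "measured", "known", "first", "only" and "open" are said of these compounds alone.

Compound 1 `COc1cc(-c2nnc3n2NC(c2ccco2)C(C(=O)c2ccccc2F)S3)cc(OC)c1OC`. In a functional assay on PC-3 cells (Homo sapiens) for cytotoxicity, read by MTT assay, with a stated time of 48 h (a higher number here means a weaker inhibitor, a lower number a stronger inhibitor), compound 1 gives only a limit of the assay, > 100000 nM. Compound 2 `COc1cc(-c2nnc3n2NC(c2ccco2)C(C(=O)c2cccs2)S3)cc(OC)c1OC` gives 46200 nM. Compound 3 `COc1cc(-c2nnc3n2NC(c2ccco2)C(C(=O)c2ccc(F)cc2)S3)cc(OC)c1OC` gives 27700 nM.

Compound 3 holds the lowest of the two numbers, but against compound 2 the gap is a 1.7-fold lower number from compound 2 to compound 3 (0.22 log units; within the scatter). Compound 4 `COc1cc(-c2nnc3n2NC(c2ccco2)C(C(=O)c2cccc4ccccc24)S3)cc(OC)c1OC` differs from compound 3 at the same carbonyl carbon where the three measured swaps took place: naphthalen-1-yl in place of 4-fluorophenyl on a carbonyl carbon. Those measured swaps gave an at least 2.1-fold lower number from compound 1 to compound 2 (0.33 log units; beyond the scatter) and an at least 3.6-fold lower number from compound 1 to compound 3 (0.55 log units; beyond the scatter), both starting from a limit (the limit of > 100000 nM in this assay, at which 1 of the 3 values shown sits), while a 1.7-fold lower number from compound 2 to compound 3 (0.22 log units; within the scatter). Changing the group on this carbonyl has therefore moved the number only modestly so far, and the step to compound 4 is expected to be a 1.1-fold higher number from compound 3 to compound 4 (0.03 log units; within the scatter). Compound 4 is estimated at 30000 nM, within 8000 nM to 100000 nM.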

Compound 4, half-maximal inhibitory concentration: > 100000 nM
Compound 4 was reported as a limit; the forecaster's own chance of this, stated with the estimate: 20%; middle value at least 3.3-fold (0.52 log units) away from the limit.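

Swapping the group on this carbonyl carbon can also weaken these compounds, which the earlier steps did not show: naphthalen-1-yl in place of 4-fluorophenyl gives an at least 3.6-fold higher number from compound 3 to compound 4 (0.55 log units; beyond the scatter), and in place of thiophen-2-yl it gives an at least 2.1-fold higher number from compound 2 to compound 4 (0.33 log units; beyond the scatter). So adding a second aromatic ring here costs activity in both readable comparisons. The step between compound 1 and compound 4 cannot be read, as both values are limits: the limit of > 100000 nM in this assay, at which 2 of the 4 values shown sit.

Still open, on these data alone, is whether an amine, a carboxylic acid or a short alkyl chain on this carbonyl would give a lower number than compound 3.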